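Bromo for methyl on the aryl of compound 2

This account rests on a few compounds, and the source may have more. Where it says the series, first, only, none or still open, it means among the compounds named here.

Measured compounds:
compound 1, `O=S(=O)(c1ccccc1)c1cnc2cc(-c3ccc(Cl)cc3)nn2c1-c1ccc(Br)cc1`, 24.2%
compound 2, `Cc1ccc(-c2c(S(=O)(=O)c3ccccc3)cnc3ncnn23)cc1`, 7.5%

In a functional assay on the whole organism for inhibition, with Mus musculus as the target, with a stated time of 1 h, at a dose of 50 mg/kg by the oral route (a lower number here means less inhibition, a higher number more inhibition at the dose given (going by the name of the read-out)), compound 1 gives 24.2% and compound 2 gives 7.5%. Compound 2 stands lowest of the two numbers; compound 1 lies higher by a margin beyond the usual scatter. Within the data shown here, the two compounds differ in more than one place, so no single step connects them and the gap is taken only as what the two values show.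

Compound 3, `O=S(=O)(c1ccccc1)c1cnc2ncnn2c1-c1ccc(Br)cc1`, has not been measured in this assay. It differs from compound 2 in one place: bromo in place of methyl on an aromatic carbon. Read one bond further out, the change is 4-methylphenyl to 4-bromophenyl. Among the measured compounds shown here, no measured step of this kind exists. Compound 1 also carries a 4-bromophenyl group and gives 24.2%, but its core differs from that of compound 2, so this is a loose pointer only.

Compound 3 is expected to show a step of a number 7.5 percentage points higher from compound 2 to compound 3 (within the scatter), a small rise that is not clearly beyond the scatter. The estimate for compound 3 is 15%, with a range from 0% to 35%.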

Compound 3, a percentage reported as inhibition, in the whole organism at one dose (the size of the read-out at that dose, not a potency): 2.2%
Estimate against measurement, compound 3: 12.8 percentage points above; the range from low to high includes it.
By their numbers in this assay, from the lowest: compounds 3 and 2 (each within the scatter of the next); then compound 1.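

In this assay, among these compounds, the change from 4-methylphenyl to 4-bromophenyl on the shared core gives a number 5.3 percentage points lower from compound 2 to compound 3 (within the scatter), the first step that isolates a single place. On this aromatic carbon, para to a large group, bromo and methyl therefore cannot be told apart in this whole-organism read-out at the dose given, and compound 2 and compound 3 cannot be put in order. No measured information on the compounds bears on this result, so the step stays a bare observation.

On these data alone, what remains open is whether this position responds to any substituent in this read-out, since methyl and bromo are both single-atom groups with no hydrogen-bond donors or acceptors, and an amine or a carboxylic acid in the same place on the shared core would put that question to a different kind of group. As far as these compounds go, it is also open whether bromo in place of methyl reads the same way on the core of compound 1, as this single pair speaks only for the core of compound 2 and compound 3.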